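This account rests on a few compounds, and the source may have more. Where it says the series, first, only, none or still open, it means among the compounds named here.

Compound 1 `O=C(O)c1cc(=O)c2ccc(OCCCN3CCC(=C(c4ccccc4)c4ccccc4)CC3)cc2o1`: 20400 nM
Compound 2 `O=C(O)c1cc(=O)c2ccc(OCCCN3CCC(C(O)(c4ccccc4)c4ccccc4)CC3)cc2o1`: 22800 nM
Compound 3 `O=C(O)c1cc(=O)c2ccc(OCCCN3CCC(OC(c4ccccc4)c4ccccc4)CC3)cc2o1`: 1450 nM

Of the compounds shown here, three with a shared core have been measured in a functional assay (ileum) for inhibition, with Cavia porcellus as the target; a higher number here means a weaker inhibitor, a lower number a stronger inhibitor. Among them compound 1 stands second highest of the three numbers. Its nearest neighbour is compound 2, whose value lies within the usual scatter of that of compound 1, so no order can be read from the two. Compound 3 gives a lower number than compound 1 by a margin beyond the scatter. No pair of these compounds differs in only one place, so no single structural step has been measured.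

Compound 4 `O=c1cc(C2N=NN=N2)oc2cc(OCCCN3CCC(=C(c4ccccc4)c4ccccc4)CC3)ccc12` is the next compound to be tested in this assay. It differs from compound 1 by a group of 5 heavy atoms (1 carbon, 4 nitrogen; one five-membered non-aromatic ring with 4 hetero atoms) in place of a group of 3 heavy atoms (1 carbon, 2 oxygen; no ring), on an aromatic carbon. Going by the values given here, no measured pair shows this change, so the expectation rests on compound 1 alone. The step from compound 1 to compound 4 is expected to be small, toward a somewhat lower number, and may well stay within the scatter, as a 1.5-fold lower number from compound 1 to compound 4 (0.16 log units; within the scatter). Compound 4 is therefore estimated at 14000 nM, with a range from 4500 nM to 45000 nM.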

Compound 4, half-maximal inhibitory concentration: 190 nM
Beside the measured number, compound 4's estimate is 74-fold (1.87 log units) above it; the measured number lies below the stated range.
By their numbers in this assay, from the lowest: compound 4; then compound 3; then compounds 1 and 2 (each within the scatter of the next).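

In this assay, putting the five-membered non-aromatic ring with 4 hetero atoms in place of the carboxy group, on the aromatic carbon next to the ring oxygen, gives a 110-fold lower number from compound 1 to compound 4 (2.03 log units; beyond the scatter), a large step beyond the scatter. Compound 1, compound 2 and compound 3 all carry the carboxy group, so they could not show that the number responds so strongly to the group at this position. Nothing at hand accounts for the size of this step.

The compounds shown leave open how a methyl ester or a primary amide at this position would compare with either group. They also leave open whether the same exchange would give a step of similar size on compound 3, which carries a different group on the far ring.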